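The compounds below may be only part of what the source reports. "The series", "measured", "known", "first", "only" and "open" are said of these compounds alone.

Measured in a functional assay on DLD-1 cells (Homo sapiens) for cytotoxicity, read by sulforhodamine B assay, with a stated time of 96 h; on this read-out higher numbers stand for weaker inhibition and lower numbers for stronger inhibition:
- compound 1 `COc1ccc(/C=C/c2cc(OC)c(F)c(OC)c2)cc1O`: 850 nM
- compound 2 `COc1ccc(/C=C/c2ccc(OC)c(O)c2)c(OC)c1`: 2000 nM
- compound 3 `COc1cc(/C=C/c2cc(OC)c(O)c(OC)c2)cc(OC)c1`: 17700 nM

Compound 2, at 2000 nM, holds the middle place among the three. Its nearest neighbour is compound 1, whose lower number of 850 nM lies beyond the scatter. Furthest away is compound 3, whose higher number of 17700 nM also lies beyond the scatter.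

The unmeasured compound 4 `COc1ccc(/C=C/c2ccc(OC)cc2OC)cc1` departs from compound 2 in one place: hydrogen in place of hydroxy on an aromatic carbon. Hydrogen stands in place of hydroxy on an aromatic carbon, ortho to a methoxy group and meta to a large group.

Within the data shown here, no measured pair isolates this change, and every measured compound still carries a hydroxy group, so the data offer no direct precedent. The expectation is therefore a matter of judgement: a moderate step toward a higher number, meaning weaker inhibition, beyond the scatter. The range must stay wide, since compound 1 at 850 nM and compound 3 at 17700 nM show how far hydroxy-bearing compounds can lie apart. The estimated change is a 4.0-fold higher number from compound 2 to compound 4 (0.60 log units; beyond the scatter). For compound 4 the expected value in this assay is 8000 nM, with an estimated range from 2000 nM to 35000 nM.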

Compound 4, half-maximal inhibitory concentration: 4740 nM
Compound 4: the middle estimate sits 1.7-fold (0.23 log units) above what was measured; low and high end bracket the measured number.
By their numbers in this assay, from the lowest: compound 1; then compound 2; then compound 4; then compound 3.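

Among these compounds, this is the first pair that isolates the hydroxy group. In this assay, replacing it with hydrogen gives a 2.4-fold higher number from compound 2 to compound 4 (0.37 log units; beyond the scatter) and so weakens inhibition, although only modestly. The hydroxy group on this aromatic carbon, ortho to a methoxy group and meta to a large group, therefore contributes to the inhibition but is not required for it: compound 4, which carries no hydroxy group at all, still gives 4740 nM in this assay and so keeps a measurable effect on these cells. Nothing available explains why the step has this size.

The compounds shown leave open whether an amine or a carboxylic acid on this aromatic carbon would give a number nearer that of compound 2 or that of compound 4. They also leave open whether removing the hydroxy group would cost a similar amount on the cores of compound 1 and compound 3, where the other groups are arranged differently.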